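Replacing the furanylmethyl group on the amine of compound 2

This account rests on a few compounds, and the source may have more. Where it says the series, first, only, none or still open, it means among the compounds named here.

Going by the values given here, compound 2 `c1cc(CNC2CCN(CCCc3c[nH]c4ccc(-n5cnnc5)cc34)CC2)co1` gives 7.1 nM in an assay on CHO cells for agonist activity at 5-hydroxytryptamine receptor 1D (Homo sapiens), read by GTPgammaS binding (a lower number here means that less compound is needed, a higher number that more compound is needed for the effect), the highest of the two numbers measured so far; compound 1 `CC(=O)Nc1ccc([C@H](C)NCC2CCN(CCCc3c[nH]c4ccc(-n5cnnc5)cc34)CC2)cc1` gives 3 nM, a lower value that lies beyond the usual scatter. Compound 3 `CC(CO)(NC1CCN(CCCc2c[nH]c3ccc(-n4cnnc4)cc23)CC1)c1ccccc1` has not yet been measured. It differs from compound 2 in one place: 1-(hydroxymethyl)-1-phenylethyl in place of (furan-3-yl)methyl on an amine nitrogen. Among the compounds with values here, no step between measured compounds matches this change, so its effect is open. A modest downward step is expected a 1.4-fold lower number from compound 2 to compound 3 (0.15 log units; within the scatter). Compound 3 is estimated at 5 nM, with a range from 1.5 nM to 20 nM.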

Compound 3, half-maximal effective concentration: 3.4 nM
Compound 3: middle estimate off by 1.5-fold (0.17 log units), on the high side; the range from low to high includes it.
By their numbers in this assay, from the lowest: compounds 1 and 3 (each within the scatter of the next); then compound 2.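

In this assay, the amine nitrogen on the saturated ring carbon accepts a larger, branched substituent: 1-(hydroxymethyl)-1-phenylethyl in place of (furan-3-yl)methyl gives a 2.1-fold lower number from compound 2 to compound 3 (0.32 log units; beyond the scatter). The change replaces a five-membered aromatic ring with a six-membered aromatic ring of carbon only and also adds a hydrogen-bond donor, so the step reflects these differences together. Nothing available explains the step.

Whether the hydroxymethyl group or the phenyl ring accounts for it remains open. A plain 1-phenylethyl group on the same nitrogen would separate the two.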